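This account rests on a few compounds, and the source may have more. Where it says the series, first, only, none or still open, it means among the compounds named here.

Of the compounds shown here, three that share one core have been tested in an assay on isolated protein (Oryctolagus cuniculus) with Thromboxane-A synthase (Homo sapiens) as the target, tested at 1 uM; on this read-out lower numbers stand for less inhibition and higher numbers for more inhibition at the one concentration tested (going by the name of the read-out). Compound 1 `CC(C)n1nc(-c2cccnc2)c2ccccc2c1=O` gives 87%, compound 2 `O=c1c2ccccc2c(-c2cccnc2)nn1Cc1ccccc1` gives 97%, and compound 3 `COCCn1nc(-c2cccnc2)c2ccccc2c1=O` gives 55%. Compound 3 thus stands lowest of the three numbers. Its nearest neighbour is compound 1, separated by a number 32 percentage points lower from compound 1 to compound 3 (beyond the scatter), and its furthest is compound 2, separated by a number 42 percentage points lower from compound 2 to compound 3 (beyond the scatter), while the remaining step, a number 10 percentage points higher from compound 1 to compound 2 (within the scatter), is one the scatter can account for. Compound 4 `O=C(c1cccs1)n1nc(-c2cccnc2)c2ccccc2c1=O` has not yet been measured. It differs from compound 3 in one place: (thiophen-2-yl)carbonyl in place of 2-methoxyethyl on an aromatic nitrogen. The two steps that bear on this change are the ones that end at compound 3; both were large and both ran downward toward the 2-methoxyethyl group that now leaves. For the measured compounds named here, since compound 3 holds the lowest number and the other two substituents on this nitrogen gave higher numbers beyond the scatter, a rise in this assay is expected for compound 4, although none of the measured compounds carries a carbonyl group on that nitrogen, so the size of the rise is uncertain. The expected step is a number 20 percentage points higher from compound 3 to compound 4 (beyond the scatter). Compound 4 is therefore estimated at 75% in this assay, with a range from 45% to 95%.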

Compound 4, a percentage reported as inhibition, at one concentration (the size of the read-out at that concentration, not a potency): 37%
Estimate against measurement, compound 4: 38 percentage points above; the whole stated range lies above it.
By their numbers in this assay, from the lowest: compound 4; then compound 3; then compounds 1 and 2 (each within the scatter of the next).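

In this assay, compound 4 holds the lowest number of the four, and the step from the 2-methoxyethyl compound is a number 18 percentage points lower from compound 3 to compound 4 (beyond the scatter), while the steps from the other two are larger: a number 60 percentage points lower from compound 2 to compound 4 (beyond the scatter) and a number 50 percentage points lower from compound 1 to compound 4 (beyond the scatter). This shows that the 2-methoxyethyl group does not mark the bottom of the range at this position, and that a five-membered aromatic ring with a carbonyl on the aromatic nitrogen can take the number lower still, whereas the benzyl group, which also brings an aromatic ring, stands at the top of the series. Nothing measured here accounts for this fall.

The compounds shown do not separate the carbonyl from the thiophene ring, as each of them carries both or neither, so it stays open whether an acetyl group or a thiophen-2-ylmethyl group on this nitrogen would read low or high. On these data alone, it is also open how a chain ending in an amine or a carboxylic acid would compare with the 2-methoxyethyl group at this position.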